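Swapping the Pyridyl Group: Expected Stability of Compound 4

The source may report more compounds than this note shows. Statements on the series, on what has been measured and on what is new or still open speak of the compounds shown alone.

Compound 1 `COc1nc2ccc(Br)cc2cc1[C@@H](c1ccnc(OC)c1OC)[C@@](O)(CCN(C)C)c1cccc(OC(F)F)c1`: 1.02 h
Compound 2 `CCSc1ccc([C@H](c2cc3cc(Br)ccc3nc2OC)[C@@](O)(CCN(C)C)c2cccc(F)c2)cn1`: 1.07 h
Compound 3 `COc1nc2ccc(Br)cc2cc1[C@@H](c1ccnc(OC)c1OC)[C@@](O)(CCN(C)C)c1cccc(C#N)c1`: 0.617 h

These three compounds were tested in an ADME assay on microsomes from liver (Homo sapiens) for metabolic stability; a lower number here means that the compound disappears faster, a higher number that the compound lasts longer. Compound 2 shows the highest of the three numbers, yet its distance to compound 1 and to compound 3 lies within the scatter, so the three are in effect indistinguishable. Going by the values given here, the only single-point step measured, a 1.7-fold lower number from compound 1 to compound 3 (0.22 log units; within the scatter), concerns a change at a different position and is itself within the scatter.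

Compound 4 `COc1nc2ccc(Br)cc2cc1[C@@H](c1cccnc1N(C)C)[C@@](O)(CCN(C)C)c1cccc(F)c1` differs from compound 2 in one place: 2-(dimethylamino)pyridin-3-yl in place of 6-(ethylsulfanyl)pyridin-3-yl on a saturated chain carbon bound to an aromatic carbon and a saturated chain carbon. Among the compounds with values here, no measured step touches this position, so the prediction rests on the tight range of the three values. A step of a 1.1-fold lower number from compound 2 to compound 4 (0.03 log units; within the scatter) is expected, that is, no change beyond the scatter. Compound 4 is therefore estimated at 1 h, in the range 0.5 h to 2 h in this assay.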

Compound 4, half-life: 0.25 h
Compound 4: the middle estimate sits 4.0-fold (0.60 log units) above what was measured; the whole stated range lies above it.
By their numbers in this assay, from the lowest: compound 4; then compounds 3, 1 and 2 (each within the scatter of the next).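

In this assay this place is sensitive: replacing 6-(ethylsulfanyl)pyridin-3-yl with 2-(dimethylamino)pyridin-3-yl gives a 4.3-fold lower number from compound 2 to compound 4 (0.63 log units; beyond the scatter) and so moves the number beyond the scatter. The two groups match in heavy-atom count and in hydrogen-bond donors and acceptors, so these counts do not track the step. Nothing available explains the step. As far as these compounds go, it remains open whether the lower number goes with the arrival of dimethylamino or the loss of ethylsulfanyl. From the compounds shown here alone, how a morpholine or an unsubstituted pyridin-3-yl would read here is also open.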